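The source may report more compounds than this note shows. Statements on the series, on what has been measured and on what is new or still open speak of the compounds shown alone.

Measured so far:
compound 1 `OC[C@H]1O[C@@H](n2cnc3c(NCc4ccc(Cl)cc4)ncnc32)[C@H](O)[C@@H]1O`: > 166000 nM
compound 2 `OC[C@H]1O[C@@H](n2cnc3c(NCc4c(F)ccc(F)c4F)ncnc32)[C@H](O)[C@@H]1O`: "not determined" (no result reported)

Both compounds share a sugar-bearing core carrying a substituted benzyl group on an aromatic nitrogen. In a functional assay on HOS cells (Homo sapiens) for antiproliferative activity, with a stated time of 72 h (on this read-out higher numbers stand for weaker inhibition and lower numbers for stronger inhibition), compound 1 gives > 166000 nM, which is a limit of the assay rather than a number. Compound 2 has no result in this assay. Within the data shown here, compound 1 therefore stands at the limit of > 166000 nM in this assay, at which 1 of the 2 values shown sits, and no measured step between compounds exists here.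

Compound 3 `OC[C@H]1O[C@@H](n2cnc3c(NCc4cccc(C(F)(F)F)c4)ncnc32)[C@H](O)[C@@H]1O` is not yet measured. It differs from compound 1 by 3-(trifluoromethyl)phenyl in place of 4-chlorophenyl on a saturated chain carbon bound to a nitrogen on an aromatic ring. Among the measured compounds shown here, with only a limit available for compound 1 and no measured step to lean on, the expected step is a step that the limit leaves unreadable from compound 1 to compound 3, that is, none beyond the scatter, and most probably the assay will again report only a limit. Compound 3 is therefore estimated at 200000 nM, with a range from 50000 nM to 1000000 nM.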

Compound 3, half-maximal inhibitory concentration: > 166000 nM
Compound 3 was reported as a limit; the forecaster's own chance of this, stated with the estimate: 80%; the middle value does not contradict the limit.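

In this assay, compound 1 and compound 3 both end at a limit rather than a number, so no step between them can be read: the limit of > 166000 nM in this assay, at which 2 of the 3 values shown sit.

From the compounds shown here alone, how 3-(trifluoromethyl)phenyl and 4-chlorophenyl truly compare stays open, as does whether any group in this place gives a measurable value in this assay.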